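Aryl group variation at the shared core: compound 4

A few compounds are considered here, and "the series" means these few. Any claim that something is new, unique, unknown or untested is made for them only; others in the source may bear on it.

Among the compounds with values here, compound 3 `CCCCCCC(Sc1nc(Cl)cc(Nc2nc(-c3ccc(Cl)cc3Cl)cs2)n1)C(=O)O` gives 800 nM in an assay for inhibition of Polyunsaturated fatty acid 5-lipoxygenase (Homo sapiens), read by HPLC, with stated times of 15 min and 10 min (a higher number here means a weaker inhibitor, a lower number a stronger inhibitor), the second highest of the three numbers so far; its neighbours are compound 2 `CCCCCCC(Sc1nc(Cl)cc(Nc2nc(-c3ccc([N+](=O)[O-])cc3)cs2)n1)C(=O)O` at 1400 nM and compound 1 `CCCCCCC(Sc1nc(Cl)cc(Nc2nc(-c3cccc4ccccc34)cs2)n1)C(=O)O` at 400 nM, both within the usual scatter of compound 3 (a 2.0-fold higher number from compound 1 to compound 3 (0.30 log units; within the scatter); a 1.8-fold lower number from compound 2 to compound 3 (0.24 log units; within the scatter)). Compound 4 `CCCCCCC(Sc1nc(Cl)cc(Nc2nc(-c3ccc(OC)cc3)cs2)n1)C(=O)O` carries 4-methoxyphenyl in place of 2,4-dichlorophenyl on an aromatic carbon. Within the data shown here, no measured step involves this group; the nearest comparisons are the aryl swaps already made, of which only a 3.5-fold higher number from compound 1 to compound 2 (0.54 log units; beyond the scatter) lies beyond the scatter. For compound 4 a step within the scatter is therefore expected, a 1.1-fold higher number from compound 3 to compound 4 (0.05 log units; within the scatter), with a wide band around it. Compound 4 is estimated at 900 nM, between 350 nM and 2500 nM in this assay.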

Compound 4, half-maximal inhibitory concentration: 800 nM
For compound 4 the middle estimate is 1.1-fold (0.05 log units) above the measured one; the measured number falls inside the stated range.
By their numbers in this assay, from the lowest: compounds 1, 3, 4 and 2 (each within the scatter of the next, the first and the last beyond it).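

Replacing 2,4-dichlorophenyl with 4-methoxyphenyl removes both chlorine atoms and adds a hydrogen-bond acceptor, yet this assay shows no change at the digits printed from compound 3 to compound 4 (within the scatter). Within the data shown here, the other two comparisons, a 1.8-fold lower number from compound 2 to compound 4 (0.24 log units; within the scatter) and a 2.0-fold higher number from compound 1 to compound 4 (0.30 log units; within the scatter), also stay within the scatter, so no step to compound 4 separates it from the other aryl groups. Nothing available explains this tolerance at the position.

Still open, on these data alone, is whether an amine or a carboxylic acid on this phenyl ring would fit as readily. Also open, as far as these compounds go, is whether a small alkyl group could replace the aryl ring altogether.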